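This account rests on a few compounds, and the source may have more. Where it says the series, first, only, none or still open, it means among the compounds named here.

Measured so far in an ADME assay on HeLa cells (Homo sapiens) for cytotoxicity, read by MTT assay, with a stated time of 48 h; a higher number here means a weaker inhibitor, a lower number a stronger inhibitor:
Compound 1 `O=[N+]([O-])c1ccc(C[Se]c2nnnn2C2CCCCC2)c([N+](=O)[O-])c1` gives 29000 nM.
Compound 2 `O=[N+]([O-])c1cc(C[Se]c2nnnn2Cc2ccccc2)cc([N+](=O)[O-])c1` gives only the limit > 30000 nM, so no number is known for it.

Compound 2 thus stands at the limit of > 30000 nM in this assay, at which 1 of the 2 values shown sits. Whether it is weaker than compound 1 cannot be told from these values. Compound 3 `COc1ccc(-n2nnnc2[Se]Cc2cc([N+](=O)[O-])cc([N+](=O)[O-])c2)cc1` differs from compound 2 by 4-methoxyphenyl in place of benzyl on an aromatic nitrogen. Within the data shown here, no measured step covers this change, so no shift beyond the usual scatter is expected in either direction. Compound 3 is therefore estimated at 30000 nM, between 15000 nM and 60000 nM, with a real chance that only a limit is again reported. The step from compound 2 to compound 3 is expected to be a number no higher from compound 2 to compound 3 (the limit leaves the size open).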

Compound 3, half-maximal inhibitory concentration: > 30000 nM
Compound 3 was reported as a limit (the forecaster's own chance of this, stated with the estimate: 55%); the middle value lies on the limit itself.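

Compound 2 and compound 3 are both reported only as limits, so no step can be read between them: the limit of > 30000 nM in this assay, at which 2 of the 3 values shown sit. In this assay the compounds shown leave open whether 4-methoxyphenyl in place of benzyl on an aromatic nitrogen changes the value at all.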